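Urea series: amine to ether on the nitrogen side chain

The compounds below may be only part of what the source reports. "The series", "measured", "known", "first", "only" and "open" are said of these compounds alone.

Compound 1 `CCCCCCCN(CCOCCSc1nc(-c2ccc(OC)cc2)c(-c2ccc(OC)cc2)[nH]1)C(=O)NC(C)C`: 850 nM
Compound 2 `CCCCCCCN(CCCCCSc1nc(-c2ccc(OC)cc2)c(-c2ccc(OC)cc2)[nH]1)C(=O)CC1CCCCC1`: 11 nM
Compound 3 `CCN(CC)CCN(CCCCCSc1nc(-c2ccccc2)c(-c2ccccc2)[nH]1)C(=O)NC(C)C`: 660 nM

In an assay on microsomes from liver with sterol O-acyltransferase 1 (Rattus norvegicus) as the target (a higher number here means a weaker inhibitor, a lower number a stronger inhibitor), compound 3 gives 660 nM. Among the three measured compounds it holds the second highest number; the nearest is compound 1 with 850 nM, and that gap lies within the scatter, so no order between compound 3 and compound 1 can be read from this assay. The furthest is compound 2 with 11 nM, a gap well beyond the scatter, but compound 2 differs from compound 3 in several places at once, so that gap is not a single step.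

Compound 4 `CCOCCOCCN(CCCCCSc1nc(-c2ccccc2)c(-c2ccccc2)[nH]1)C(=O)NC(C)C` is not yet measured in this assay. It differs from compound 3 by 2-ethoxyethoxy in place of diethylamino on a saturated chain carbon, two bonds along the chain from an amide-type nitrogen. Among the compounds with values here, no measured pair in the set isolates this change; compound 1 carries an ether in a different part of the molecule and is not a reference for it. Within the data shown here, with no comparable step available, the expected change is small, of the size a 1.2-fold higher number from compound 3 to compound 4 (0.08 log units; within the scatter), and not beyond the scatter. Compound 4 is therefore estimated at 800 nM in this assay, with a range from 250 nM to 2500 nM.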

Compound 4, half-maximal inhibitory concentration: 30 nM
Compound 4: middle estimate off by 27-fold (1.43 log units), on the high side, outside the stated range (below it).
By their numbers in this assay, from the lowest: compound 2; then compound 4; then compounds 3 and 1 (each within the scatter of the next).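

Placing 2-ethoxyethoxy in place of diethylamino on a saturated chain carbon, two bonds along the chain from an amide-type nitrogen, gives a 22-fold lower number from compound 3 to compound 4 (1.34 log units; beyond the scatter) in this assay and so shows that this side chain position is sensitive to the group it carries. The earlier compounds shown here differ in several places at once, so none of them could show the effect of this position alone. Nothing available here explains the size of this step.

A plain hexyl chain or a 2-methoxyethyl group at this position would help separate the part played by the ether oxygens from that played by the removal of diethylamino. Going by these compounds, whether the same change holds on the core of compound 1 also remains open.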